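The source may hold more compounds than are shown below. What is called first, only, known or untested is meant among the compounds shown, and "the series" means these compounds.

Compound 1 `COC(=O)c1sc(-c2ccc(Cl)cc2)nc1C(Br)Br` carries a methoxy on a carbonyl carbon attached to the shared core. Within the data shown here, in an ADME assay on BHK15 cells (Mesocricetus auratus) for inhibition, read by XTT assay, with a stated time of 36 h (on this read-out higher numbers stand for weaker inhibition of growth and lower numbers for stronger inhibition of growth), compound 1 gives 222000 nM, the second highest of the three numbers measured so far. Compound 2 `CC(C)OC(=O)c1sc(-c2ccc(Cl)cc2)nc1C(Br)Br` gives 372000 nM, and compound 3 `CC(=O)c1sc(-c2ccc(Cl)cc2)nc1C(Br)Br` gives 83500 nM. The step of a 1.7-fold higher number from compound 1 to compound 2 (0.22 log units; within the scatter) stays within the scatter, whereas the step of a 2.7-fold lower number from compound 1 to compound 3 (0.42 log units; beyond the scatter) lies beyond it, as does the step of a 4.5-fold lower number from compound 2 to compound 3 (0.65 log units; beyond the scatter). Compound 4 `CN(C)/C=C/C(=O)c1sc(-c2ccc(Cl)cc2)nc1C(Br)Br` has not yet been measured. It differs from compound 1 in one place: 2-(dimethylamino)ethenyl in place of methoxy on a carbonyl carbon. Both the move to compound 3 and the move to compound 4 replace the methoxy on the carbonyl carbon, so the step of a 2.7-fold lower number from compound 1 to compound 3 (0.42 log units; beyond the scatter) is the one that bears on this case; it was modest and went towards stronger inhibition of growth. A step of similar size in the same direction is therefore expected, estimated as a 3.0-fold lower number from compound 1 to compound 4 (0.47 log units; beyond the scatter). Compound 4 is expected to give about 75000 nM, with a range from 25000 nM to 220000 nM.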

Compound 4, concentration for 50% growth inhibition: 38200 nM
The estimate for compound 4 lay 2.0-fold (0.29 log units) above the measured number; the measured number falls inside the stated range.
By their numbers in this assay, from the lowest: compound 4; then compound 3; then compounds 1 and 2 (each within the scatter of the next).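

Replacing the methoxy on the carbonyl carbon with 2-(dimethylamino)ethenyl produces the strongest inhibition of growth of the four compounds in this assay (a 5.8-fold lower number from compound 1 to compound 4 (0.76 log units; beyond the scatter); a 9.7-fold lower number from compound 2 to compound 4 (0.99 log units; beyond the scatter)). The position therefore tolerates a group longer than methyl, and this change goes further than methyl does (a 2.2-fold lower number from compound 3 to compound 4 (0.34 log units; beyond the scatter)), so the two compounds with carbon on the carbonyl carbon, compound 3 and compound 4, both give lower numbers than the two with oxygen there, compound 1 and compound 2. No measurement here explains why this change lowers the number.

The compounds shown cannot separate the part played by the dimethylamino nitrogen from that of the double bond, which a saturated 2-(dimethylamino)ethyl chain on the carbonyl carbon would help to do. On these data alone, how an amine attached directly to the carbonyl carbon, forming an amide, would compare also remains open.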